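The source may report more compounds than this note shows. Statements on the series, on what has been measured and on what is new or still open speak of the compounds shown alone.

Compound 3, drawn as `CCOC(=O)c1cc(=O)oc2cc(OCc3cccc(Cl)c3)ccc12`, gives 4.4% in an assay on isolated protein (strain Sprague-Dawley) for inhibition of Amine oxidase [flavin-containing] A (Rattus norvegicus), read by spectrophotometry, with a stated time of 5 min, tested at 10 uM; on this read-out lower numbers stand for less inhibition and higher numbers for more inhibition at the one concentration tested (going by the name of the read-out). Among the three measured compounds it stands second highest: the nearest is compound 1, `CCNC(=O)Nc1cc(=O)oc2cc(OCc3cccc(Cl)c3)ccc12`, with 0%, a gap within the usual scatter, and the furthest is compound 2, `O=c1cc(CCl)c2ccc(OCc3cccc(Cl)c3)cc2o1`, with 21%, a gap beyond it. The measured steps are a number 21 percentage points higher from compound 1 to compound 2 (beyond the scatter), a number 4.4 percentage points higher from compound 1 to compound 3 (within the scatter) and a number 16.6 percentage points lower from compound 2 to compound 3 (beyond the scatter).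

Compound 4, `NC(=O)c1cc(=O)oc2cc(OCc3cccc(Cl)c3)ccc12`, differs from compound 3 by amino in place of ethoxy on a carbonyl carbon. Within the data shown here, no measured step alters this part of the molecule; the nearest comparison is the one from compound 1 to compound 3, where one carbonyl-bearing group replaced another on the aromatic carbon and the read-out stayed within the scatter. On that basis no step beyond the scatter is expected in this assay, in either direction. Compound 4 is therefore estimated at 5%, between 0% and 18%, meaning an expected step of a number 0.6 percentage points higher from compound 3 to compound 4 (within the scatter).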

Compound 4, a percentage reported as inhibition, at one concentration (the size of the read-out at that concentration, not a potency): 14%
For compound 4 the middle estimate is 9 percentage points below the measured one, within the range that was stated.
By their numbers in this assay, from the lowest: compounds 1, 3, 4 and 2 (each within the scatter of the next, the first and the last beyond it).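

In this assay, among these compounds, the carbonyl carbon itself is varied for the first time, and amino in place of ethoxy there gives a step that stays within the scatter (a number 9.6 percentage points higher from compound 3 to compound 4 (within the scatter)). On the aromatic carbon, carbamoyl does not separate from chloromethyl (a number 7 percentage points lower from compound 2 to compound 4 (within the scatter)), although ethoxycarbonyl did, and it does separate from (ethylcarbamoyl)amino (a number 14 percentage points higher from compound 1 to compound 4 (beyond the scatter)), although ethoxycarbonyl did not, so carbamoyl and ethoxycarbonyl, themselves within the scatter of each other, relate differently to these two neighbours. No measurement is at hand that accounts for any of these steps.

Open, as far as these compounds go, is how a methylamino or dimethylamino group on the same carbonyl carbon would read, or a hydroxy group, which would make a carboxylic acid. These readings at one concentration also leave the potency of compound 4 undetermined.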